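This account rests on a few compounds, and the source may have more. Where it says the series, first, only, none or still open, it means among the compounds named here.

Compound 1 `Cc1ccc(-c2ccnc(Nc3ccc4c(c3)c(/C=C3/C(=O)Nc5ccccc53)cn4C)n2)cc1` gives in a functional assay on MCF7 cells (Homo sapiens) for cytotoxicity, read by MTT assay, with a stated time of 48 h (a lower number here means a stronger inhibitor, a higher number a weaker inhibitor), only a limit, > 100000 nM, so no number is known for compound 1 itself. Its value sits at the limit of > 100000 nM in this assay, at which 1 of the 2 values shown sits. Compound 2 `Cn1cc(/C=C2/C(=O)Nc3ccccc32)c2cc(Nc3nccc(-c4ccc(O)cc4)n3)ccc21`, with hydroxy in place of methyl on an aromatic carbon, gives 39600 nM in this assay, which is an at least 2.5-fold lower number from compound 1 to compound 2 (0.40 log units; beyond the scatter). The unmeasured compound 3 `Cn1cc(/C=C2/C(=O)Nc3ccccc32)c2cc(Nc3nccc(-c4ccc(Cl)cc4Cl)n3)ccc21` carries 2,4-dichlorophenyl in place of 4-methylphenyl on an aromatic carbon. Among the compounds with values here, no measured step covers this change; the step from compound 1 to compound 2 bears on it only in showing that a change at this place can move the number beyond the scatter, and its direction cannot be carried over to a different group. Compound 3 is therefore expected to remain weak, with its number in this assay estimated at 70000 nM, between 25000 nM and 200000 nM. That estimate means an at least 1.4-fold lower number from compound 1 to compound 3 (0.15 log units; that floor lies within the scatter), a step expected to be small, if any, beyond the scatter.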

Compound 3, half-maximal inhibitory concentration: > 100000 nM
Compound 3 was reported as a limit; the forecaster's own chance of this, stated with the estimate: 45%; middle value at least 1.4-fold (0.15 log units) away from the limit.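

In this assay compound 3 gives > 100000 nM, which is a limit and not a number. Placing 2,4-dichlorophenyl in place of 4-hydroxyphenyl on this aromatic carbon gives an at least 2.5-fold higher number from compound 2 to compound 3 (0.40 log units; beyond the scatter), so of the three aryl groups shown, only 4-hydroxyphenyl gives a number rather than a limit. The step between compound 1 and compound 3 cannot be read, and readings at this position now mostly stop at the assay ceiling: the limit of > 100000 nM in this assay, at which 2 of the 3 values shown sit.

Open, on these data alone, is whether the lower number of compound 2 is specific to the hydroxy group or would also appear with an amine, a methoxy group or a carboxylic acid on the same phenyl ring. Also open, as far as these compounds go, is how far apart the 4-methylphenyl and 2,4-dichlorophenyl groups truly lie in this assay.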